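This account rests on a few compounds, and the source may have more. Where it says the series, first, only, none or still open, it means among the compounds named here.

Three measured compounds share one core and differ only in the group on the carbonyl carbon. Compound 1 `O=C(C1CCC(F)(F)CC1)N1CC(c2nc(-c3cccc(Cl)c3)no2)C1` carries a 4,4-difluorocyclohexyl group there. In an assay on HEK293 cells for negative allosteric modulation of metabotropic glutamate receptor 5 (Homo sapiens), read by FLIPR (on this read-out higher numbers stand for weaker inhibition and lower numbers for stronger inhibition), compound 1 gives > 10000 nM, which is a limit of the assay rather than a number. Compound 2 `CC1CCC(C(=O)N2CC(c3nc(-c4cccc(Cl)c4)no3)C2)CC1` carries a 4-methylcyclohexyl group. In this assay compound 2 gives > 10000 nM, again a limit. Compound 3 `O=C(c1ccccc1F)N1CC(c2nc(-c3cccc(Cl)c3)no2)C1` carries a 2-fluorophenyl group and is the only one of the three with a number: in this assay compound 3 gives 670 nM.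

Compound 4 `CC1CN(C(=O)N2CC(c3nc(-c4cccc(Cl)c4)no3)C2)CC(C)O1` is not yet measured and differs from compound 3 by 2,6-dimethylmorpholin-4-yl in place of 2-fluorophenyl on a carbonyl carbon. Within the data shown here, the steps that bear on this change are an at least 14-fold lower number from compound 1 to compound 3 (1.17 log units; beyond the scatter) and an at least 14-fold lower number from compound 2 to compound 3 (1.17 log units; beyond the scatter): in both, a six-membered non-aromatic ring gave way to the 2-fluorophenyl, and both lowered the number well beyond the scatter. The change to compound 4 again places a six-membered non-aromatic ring on the carbonyl carbon, so the opposite is expected: a large rise in the number, quite possibly ending at the limit of > 10000 nM in this assay, at which 2 of the 3 values shown sit. The step from compound 3 to compound 4 is expected to be a 12-fold higher number from compound 3 to compound 4 (1.08 log units; beyond the scatter). Compound 4 is therefore estimated at 8000 nM, with a likely range from 2000 nM to 30000 nM.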

Compound 4, half-maximal inhibitory concentration: 990 nM
The estimate for compound 4 lay 8.1-fold (0.91 log units) above the measured number; measured number below the stated range.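

A six-membered non-aromatic ring on the carbonyl carbon is not in itself a loss at this position: in this assay there is a 1.5-fold higher number from compound 3 to compound 4 (0.17 log units; within the scatter), so an aromatic ring is not required here. What sits in the non-aromatic ring matters, since 2,6-dimethylmorpholin-4-yl gives an at least 10-fold lower number from compound 2 to compound 4 (1.00 log units; beyond the scatter) and an at least 10-fold lower number from compound 1 to compound 4 (1.00 log units; beyond the scatter). Compound 1 and compound 2 remain at a limit of the assay and not at a number: the limit of > 10000 nM in this assay, at which 2 of the 4 values shown sit.

The compounds shown do not separate the part played by the ring oxygen from that of the two methyl groups, which morpholin-4-yl or piperidin-1-yl on the same carbonyl carbon could do. They also leave open how a piperazine ring or an open-chain diethylamino group would fare at this position.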